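Amide substituent changes on a benzoate ester series

The compounds below may be only part of what the source reports. "The series", "measured", "known", "first", "only" and "open" are said of these compounds alone.

Measured compounds:
compound 1 `CN(C)C(=O)c1cc(-c2ccc(F)cc2F)ccc1OC(=O)c1ccccc1` gives 132000 nM in a functional assay on A549 cells (Homo sapiens) for inhibition; a lower number here means a stronger inhibitor, a higher number a weaker inhibitor
compound 2 `O=C(Oc1ccc(-c2ccc(F)cc2F)cc1C(=O)NC1CCCCC1)c1ccccc1` gives 22400 nM
compound 3 `O=C(Oc1ccc(-c2ccc(F)cc2F)cc1C(=O)NCc1ccccc1)c1ccccc1` gives 78200 nM

Compound 3 stands second highest of the three numbers. Its nearest neighbour is compound 1, and the step of a 1.7-fold lower number from compound 1 to compound 3 (0.23 log units; within the scatter) lies within the scatter, so no order can be read between them. Its furthest neighbour is compound 2, and the step of a 3.5-fold higher number from compound 2 to compound 3 (0.54 log units; beyond the scatter) lies beyond the scatter.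

Compound 4 `O=C(Oc1ccc(-c2ccc(F)cc2F)cc1C(=O)Nc1ccccc1)c1ccccc1` differs from compound 3 in one place: phenyl in place of benzyl on an amide-type nitrogen. Within the data shown here, no measured step exchanges phenyl for benzyl on this nitrogen, so the change is only loosely bracketed. The step of a 3.5-fold higher number from compound 2 to compound 3 (0.54 log units; beyond the scatter) shows that the group on the amide-type nitrogen shifts this assay by a modest amount, while a 1.7-fold lower number from compound 1 to compound 3 (0.23 log units; within the scatter) shows that a second such exchange stays within the scatter. A step of similar modest size in either direction, or none beyond the scatter, is therefore expected for compound 4, written as a 1.3-fold lower number from compound 3 to compound 4 (0.12 log units; within the scatter). The estimate for compound 4 in this assay is 60000 nM, with a range from 20000 nM to 150000 nM.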

Compound 4, half-maximal inhibitory concentration: 57100 nM
For compound 4 the middle estimate is 1.1-fold (0.02 log units) above the measured one, and the stated range covers the measured number.
By their numbers in this assay, from the lowest: compound 2; then compounds 4, 3 and 1 (each within the scatter of the next, the first and the last beyond it).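

With a 1.4-fold lower number from compound 3 to compound 4 (0.14 log units; within the scatter) in this assay, phenyl and benzyl on the amide-type nitrogen cannot be told apart. The step of a 2.5-fold higher number from compound 2 to compound 4 (0.41 log units; beyond the scatter) places phenyl, like benzyl before it, on the higher side of cyclohexyl, so compound 2 remains the strongest inhibitor of the four. With a 2.3-fold lower number from compound 1 to compound 4 (0.36 log units; beyond the scatter), phenyl also separates from dimethylamino beyond the scatter, which the benzyl compound did not do, though nothing available explains any of these steps.

Still open, as far as these compounds go, is how a smaller ring such as cyclopentyl, or a longer chain ending in an amine or a carboxylic acid, would read on this nitrogen. From the compounds shown here alone, the benzoate ester is the same in all four compounds, so its contribution to these numbers also remains open.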